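Fluoro for methyl on a benzoyl-bearing imidazole series

This account rests on a few compounds, and the source may have more. Where it says the series, first, only, none or still open, it means among the compounds named here.

The account covers four compounds that share one core. Compound 1 `Cc1cncc(C(=O)n2c(-c3cn(-c4ccccc4)nc3-c3ccc(F)cc3)nc3ccccc32)c1`, compound 2 `Cc1ccc(-c2nn(-c3ccccc3)cc2-c2nc3ccccc3n2C(=O)c2cncc(C)c2)cc1` and compound 3 `Cc1ccc(-c2nn(-c3ccccc3)cc2-c2nc3ccccc3n2C(=O)c2ccc(Cl)cc2)cc1` have been measured; compound 4 `O=C(c1ccc(Cl)cc1)n1c(-c2cn(-c3ccccc3)nc2-c2ccc(F)cc2)nc2ccccc21` has not. In an ADME assay on HEK-293T cells (Homo sapiens) for cytotoxicity, read by MTT assay, with a stated time of 24 h (a higher number here means that more compound is tolerated, a lower number that less compound is tolerated), compound 1 gives 119000 nM, compound 2 gives 155000 nM and compound 3 gives 216000 nM. The step of a 1.4-fold higher number from compound 2 to compound 3 (0.14 log units; within the scatter) follows the change (4-chlorophenyl in place of 5-methylpyridin-3-yl on a carbonyl carbon), which is how the core of compound 3 differs from the core of compound 2. The step of a 1.3-fold lower number from compound 2 to compound 1 (0.11 log units; within the scatter) follows the change (fluoro in place of methyl on an aromatic carbon). Compound 4 differs from compound 3 by fluoro in place of methyl on an aromatic carbon, and since the place of that change is described in the same words as for compound 2 and compound 1, it is the same change, seen a second time on the other core. On this basis the expected step in this assay is a 1.3-fold lower number from compound 3 to compound 4 (0.12 log units; within the scatter), an expectation that rests on the measured step of a 1.3-fold lower number from compound 2 to compound 1 (0.11 log units; within the scatter). Compound 4 is therefore estimated at 165000 nM, with a range from 95000 nM to 290000 nM.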

Compound 4, half-maximal cytotoxic concentration: 179000 nM
Compound 4: the middle estimate sits 1.1-fold (0.04 log units) below what was measured, within the range that was stated.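

In this assay, the change from 4-methylphenyl to 4-fluorophenyl gives a 1.2-fold lower number from compound 3 to compound 4 (0.08 log units; within the scatter), and seen on both cores it shows no difference beyond the scatter: the same change on two cores in this assay, a 1.3-fold lower number (0.11 log units; within the scatter) from compound 2 to compound 1 and a 1.2-fold lower number (0.08 log units; within the scatter) from compound 3 to compound 4, 1.1-fold (0.03 log units) apart, within the scatter of two such steps. The change from 5-methylpyridin-3-yl to 4-chlorophenyl on the carbonyl carbon, now read a second time, gives a 1.5-fold higher number from compound 1 to compound 4 (0.18 log units; within the scatter), and it also carries from one core to the other: the same change on two cores in this assay, a 1.4-fold higher number (0.14 log units; within the scatter) from compound 2 to compound 3 and a 1.5-fold higher number (0.18 log units; within the scatter) from compound 1 to compound 4, 1.1-fold (0.03 log units) apart, within the scatter of two such steps. Among these four compounds, each change therefore behaves alike on both cores, but since every step lies within the scatter, this shows only that neither change gave a measurable step here, not that either has a step of fixed size that would hold on any other core.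

The compounds shown leave open what an amine, a carboxylic acid or a longer chain would give in place of the fluoro on the phenyl ring. They also leave open whether any such group would give a step beyond the scatter, and whether that step would carry across both cores.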